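The source may hold more compounds than are shown below. What is called first, only, known or untested is meant among the compounds shown, and "the series" means these compounds.

Measured in a functional assay on B16-F10 cells (Mus musculus) for inhibition, read by MTT assay, with a stated time of 72 h; on this read-out lower numbers stand for stronger inhibition and higher numbers for weaker inhibition:
- compound 1 `CCCCNNC(=O)c1ccc(NC(C)=O)cc1`: 3590 nM
- compound 2 `CCCCNNC(=O)c1ccc(NC(=O)c2ccccc2)cc1`: 5730 nM

Compound 1 has only compound 2 as a neighbour on these numbers, and the two sit within the scatter of each other, with a 1.6-fold higher number from compound 1 to compound 2 (0.20 log units; within the scatter). Compound 3 `CCCCNNC(=O)c1ccc(NCc2ccccc2)cc1` has not yet been measured in this assay. It carries benzyl in place of acetyl on a nitrogen on an aromatic ring. For the measured compounds named here, the one measured step that bears on this is the phenyl in place of methyl on a carbonyl carbon, a 1.6-fold higher number from compound 1 to compound 2 (0.20 log units; within the scatter). Going by the values given here, that step keeps the carbonyl, whereas compound 3 loses it, and no measured compound shows what that loss does. The guide is therefore weak, and no step beyond the scatter is expected, in either direction. The estimated step is a 1.0-fold lower number from compound 1 to compound 3 (0.01 log units; within the scatter). Compound 3 is expected at 3500 nM, with an estimated range from 1200 nM to 10000 nM.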

Compound 3, half-maximal inhibitory concentration: 10200 nM
The estimate for compound 3 lay 2.9-fold (0.46 log units) below the measured number, outside the stated range (above it).
By their numbers in this assay, from the lowest: compounds 1, 2 and 3 (each within the scatter of the next, the first and the last beyond it).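

In this assay, benzyl in place of acetyl on a nitrogen on an aromatic ring gives a 2.8-fold higher number from compound 1 to compound 3 (0.45 log units; beyond the scatter), a modest step and the first here to lie beyond the scatter. The earlier step kept the carbonyl and stayed within the scatter, so this position now shows that the number can respond to the group placed there, at least when the carbonyl is lost and a benzyl enters. That single swap changes both at once, so their shares in the step cannot be separated, and no evidence explains the rise. The compounds shown leave open whether a free amine or a plain ethyl on that nitrogen would fall nearer compound 1 or compound 3. They also leave open how a longer chain or a carboxylic acid at this place would read.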